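This account rests on a few compounds, and the source may have more. Where it says the series, first, only, none or still open, it means among the compounds named here.

Compound 1 `Cc1nn(-c2ncnc3nc[nH]c23)c2c1C(OCc1ccc(Cl)cc1Cl)CC(=O)N2` gives 4 nM in a functional assay on HEK293 cells for agonist activity at G-protein coupled receptor 39 (Homo sapiens), read by scintillation proximity assay and inositol phosphate accumulation, with a stated time of 75 min, in the presence of a further agent that is not named here; on this read-out higher numbers stand for an effect only at larger amounts of compound and lower numbers for an effect already at smaller amounts.
Compound 2 `Cc1cc(C)n(CCOC2CC(=O)Nc3c2c(C)nn3-c2ncnc3nc[nH]c23)n1` gives 16 nM in this assay.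
Compound 3 `Cc1nn(-c2ncnc3nc[nH]c23)c2c1C(C(=O)NCc1ccccc1)CC(=O)N2` gives 5 nM in this assay.

Compound 3 stands second highest of the three numbers: its nearest neighbour is compound 1, with a 1.3-fold higher number from compound 1 to compound 3 (0.10 log units; within the scatter) lying within the scatter, while a 3.2-fold lower number from compound 2 to compound 3 (0.51 log units; beyond the scatter) lies beyond it. Compound 4 `Cc1nn(-c2ncnc3nc[nH]c23)c2c1C(OCc1ccc(C#N)cc1)CC(=O)N2` differs from compound 3 by (4-cyanobenzyl)oxy in place of benzylcarbamoyl on a saturated ring carbon. The step bearing most directly on this exchange is a 1.3-fold higher number from compound 1 to compound 3 (0.10 log units; within the scatter), where (2,4-dichlorobenzyl)oxy stood in place of benzylcarbamoyl without a change beyond the scatter. In a 4.0-fold higher number from compound 1 to compound 2 (0.60 log units; beyond the scatter) the six-membered carbon aromatic ring gave way to a five-membered ring with two hetero atoms, but compound 4 keeps the six-membered ring. No step beyond the scatter is therefore expected in this assay. Compound 4 is estimated at 8 nM with a range of 2.5 nM to 25 nM. This expected step is a 1.6-fold higher number from compound 3 to compound 4 (0.20 log units; within the scatter).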

Compound 4, half-maximal effective concentration: 4 nM
Estimate against measurement, compound 4: 2.0-fold (0.30 log units) above; measured number inside the range.
By their numbers in this assay, from the lowest: compounds 1, 4 and 3 (each within the scatter of the next); then compound 2.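

In this assay the saturated ring carbon takes an oxygen-linked group as well as an amide-linked one of equal heavy-atom count, with a 1.3-fold lower number from compound 3 to compound 4 (0.10 log units; within the scatter) for (4-cyanobenzyl)oxy in place of benzylcarbamoyl. On the oxygen-linked chain, 4-cyanophenyl serves like 2,4-dichlorophenyl, with no change at the digits printed from compound 1 to compound 4 (within the scatter), while a 4.0-fold lower number from compound 2 to compound 4 (0.60 log units; beyond the scatter) for 4-cyanophenyl in place of (3,5-dimethyl-1H-pyrazol-1-yl)methyl. Nothing measured here accounts for these steps. Open, as far as these compounds go, is whether an amine or a carboxylic acid in place of the nitrile, or a longer chain on the oxygen, keeps the number in this range.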